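Swapping the Aromatic Group on the Acrylamide Arm

The source may report more compounds than this note shows. Statements on the series, on what has been measured and on what is new or still open speak of the compounds shown alone.

Compound 1 `Clc1cccc(Nc2ncnc3ccc(NCc4ccc(Br)s4)cc23)c1`, compound 2 `O=C(/C=C/c1cccnc1)Nc1ccc2ncnc(Nc3cccc(Cl)c3)c2c1` and compound 3 `O=C(/C=C/c1cccc(Br)n1)Nc1ccc2ncnc(Nc3cccc(Cl)c3)c2c1` share one core and differ in the group attached to it. In a functional assay on A549 cells (Homo sapiens) for antiproliferative activity, read by MTT assay, with a stated time of 48 h (a lower number here means a stronger inhibitor, a higher number a weaker inhibitor), compound 1 gives 820 nM, compound 2 gives 4320 nM and compound 3 gives 4160 nM. Among these three numbers compound 3 stands second highest: compound 2 lies within the scatter of it, while compound 1 lies beyond the scatter with the lower number. Among the measured compounds shown here, the only one-place step measured so far, a 1.0-fold lower number from compound 2 to compound 3 (0.02 log units; within the scatter), shows that exchanging the aromatic group on the double-bonded chain carbon left the read-out essentially unchanged.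

Compound 4 `O=C(/C=C/c1ncc2ccccc2n1)Nc1ccc2ncnc(Nc3cccc(Cl)c3)c2c1` continues the same line of change: quinazolin-2-yl in place of 6-bromopyridin-2-yl on a double-bonded chain carbon bound to a double-bonded chain carbon. For the measured compounds named here, the one measured step that bears on this change, a 1.0-fold lower number from compound 2 to compound 3 (0.02 log units; within the scatter), was small, so for compound 4 a similarly small move is expected, with nothing beyond the scatter, a 1.0-fold lower number from compound 3 to compound 4 (0.02 log units; within the scatter). Compound 4 is therefore estimated at 4000 nM in this assay, with a plausible range from 1500 nM to 11000 nM.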

Compound 4, half-maximal inhibitory concentration: 3350 nM
For compound 4 the middle estimate is 1.2-fold (0.08 log units) above the measured one; low and high end bracket the measured number.
By their numbers in this assay, from the lowest: compound 1; then compounds 4, 3 and 2 (each within the scatter of the next).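

In this assay, quinazolin-2-yl in place of 6-bromopyridin-2-yl gives a 1.2-fold lower number from compound 3 to compound 4 (0.09 log units; within the scatter), and quinazolin-2-yl in place of pyridin-3-yl gives a 1.3-fold lower number from compound 2 to compound 4 (0.11 log units; within the scatter). The earlier step exchanged one single aromatic ring for another, whereas this change brings in a group with two six-membered aromatic rings and 10 heavy atoms in place of 7, and it removes the bromine, yet the read-out still stays within the scatter. All three aromatic groups at this place on the double-bonded chain carbon therefore give numbers that cannot be told apart, although no information is available here on why the read-out stays so flat.

As far as these compounds go, all three of these groups are aromatic, so it remains open whether an amine, a carboxylic acid or a simple alkyl chain at this place would also leave the number where it is. From the compounds shown here alone, it is equally open whether the double bond in the chain matters, since compounds 2, 3 and 4 all keep it, and a saturated chain could show whether this arm affects the read-out at all.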